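Hydroxy in Place of Hydrogen on the Saturated Ring

A few compounds are considered here, and "the series" means these few. Any claim that something is new, unique, unknown or untested is made for them only; others in the source may bear on it.

compound 1 `Nc1nc(-c2cccs2)c2ncn([C@H]3C[C@H](O)[C@@H](CO)O3)c2n1`: 38000 nM
compound 2 `Nc1nc(-c2ccco2)c2ncn([C@H]3C[C@H](O)[C@@H](CO)O3)c2n1`: 290000 nM
compound 3 `OC[C@H]1O[C@@H](n2cnc3c(-c4ccco4)ncnc32)C[C@@H]1O`: 330000 nM

In a functional assay on HT-1080 cells (Homo sapiens), read by MTT assay (on this read-out lower numbers stand for stronger inhibition and higher numbers for weaker inhibition), compound 1 gives 38000 nM, the lowest of the three numbers. The two measured steps both concern the aromatic part of the shared core: a 7.6-fold higher number from compound 1 to compound 2 (0.88 log units; beyond the scatter), and a 1.1-fold higher number from compound 2 to compound 3 (0.06 log units; within the scatter). Compound 4 `Nc1nc(-c2cccs2)c2ncn([C@@H]3O[C@H](CO)[C@@H](O)[C@H]3O)c2n1` differs from compound 1 in another place: hydroxy in place of hydrogen on a saturated ring carbon. Within the data shown here, no measured step touches this saturated ring, so nothing in the data speaks to the size or direction of this change; the only comparison is to compound 1 itself. On that basis compound 4 is expected to stay within the scatter of compound 1, with wide uncertainty. The estimate for compound 4 in this assay is 40000 nM, between 10000 nM and 160000 nM, which corresponds to an expected 1.1-fold higher number from compound 1 to compound 4 (0.02 log units; within the scatter).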

Compound 4, half-maximal inhibitory concentration: 88000 nM
The estimate for compound 4 lay 2.2-fold (0.34 log units) below the measured number, within the range that was stated.
By their numbers in this assay, from the lowest: compound 1; then compound 4; then compounds 2 and 3 (each within the scatter of the next).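

In this assay, among these compounds, hydroxy in place of hydrogen on a saturated ring carbon gives a 2.3-fold higher number from compound 1 to compound 4 (0.36 log units; beyond the scatter) and so shows that the saturated ring, untouched by the earlier steps, is not silent to change. Among the compounds shown here, the step is modest and runs toward weaker inhibition, and it is the only reading for this ring. No measurement available here accounts for the shift.

On these data alone, whether a methoxy group or an amine on the same carbon would move the number in the same direction stays open. So does whether this change would give a similar step with furan-2-yl in place of thiophen-2-yl on the shared core.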